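This account rests on a few compounds, and the source may have more. Where it says the series, first, only, none or still open, it means among the compounds named here.

Measured so far in a physicochemical assay for solubility; on this read-out lower numbers stand for lower solubility and higher numbers for higher solubility:
- compound 1 `CNC(=O)c1cc(C(=O)N[C@H]2[C@@H]3COC[C@@H]32)cc2c1OC[C@H]2c1ccncc1`: >= 184 ug/mL
- compound 2 `CNC(=O)c1cc(C(N)=O)cc2c1O[C@H](CF)[C@H]2c1ccccc1`: >= 128 ug/mL
- compound 3 `CNC(=O)c1cc(C(=O)N[C@H]2[C@@H]3C[C@@H](O)C[C@@H]32)cc2c1OC[C@@]2(C)c1ccccc1`: >= 209 ug/mL

Compound 1 stands at >= 184 ug/mL, which is a limit and not a number. Going by the values given here, the entries for compound 2 and compound 3 are limits too, so no order among the three can be read, and no measured step is available for sizing a change.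

Compound 4 `CNC(=O)c1cc(C(=O)N[C@H]2[C@@H]3COC[C@@H]32)cc2c1OC[C@H]2c1ccccc1C` has not yet been measured. It differs from compound 1 by 2-methylphenyl in place of pyridin-4-yl on a saturated ring carbon.

Compound 3 has no pyridin-4-yl and still gives a limit, >= 209 ug/mL. Compound 2 also has no pyridin-4-yl and gives a limit, >= 128 ug/mL. A modest fall in this assay is therefore the expectation, and it may stay within the scatter. The estimated change is an at least 1.4-fold lower number from compound 1 to compound 4 (0.16 log units; that floor lies within the scatter). Compound 4 is expected at 125 ug/mL, with an estimated range of 45 ug/mL to 210 ug/mL.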

Compound 4, solubility: >= 103 ug/mL
Compound 4: no number, only a limit; the forecaster's own chance of this, stated with the estimate: 40%; the middle value lies beyond the limit too.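

In this assay compound 4 gives >= 103 ug/mL, which is a limit. Going by these compounds alone, compound 1 gives >= 184 ug/mL, also a limit, so no step between compound 1 and compound 4 can be read. The compounds shown leave open what size of change, if any, comes with 2-methylphenyl in place of pyridin-4-yl.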